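Cytotoxicity notes: the step to 3,4,5-trimethoxyphenyl

The compounds below may be only part of what the source reports. "The series", "measured", "known", "first", "only" and "open" are said of these compounds alone.

Compound 1 `Cn1cc(C2CC(c3ccc(F)cc3)=NN2C(=O)c2cccnc2)c2cc(Br)ccc21` gives > 300000 nM (a limit)
Compound 2 `Cn1cc(C2CC(c3ccc(Cl)cc3)=NN2C(=O)c2cccnc2)c2cc(Br)ccc21` gives > 300000 nM (a limit)
Compound 3 `COc1ccc(C2=NN(C(=O)c3cccnc3)C(c3cn(C)c4ccc(Br)cc34)C2)cc1` gives > 300000 nM (a limit)

In an ADME assay on HEK-293T cells (Homo sapiens) for cytotoxicity, read by MTT assay, with a stated time of 48 h (on this read-out higher numbers stand for lower toxicity in this test and lower numbers for higher toxicity in this test), compound 3 gives > 300000 nM as a limit and not a number. The series offers only the limit of > 300000 nM in this assay, at which 3 of the 3 values shown sit, as its evidence so far. Compound 4 `COc1cc(C2=NN(C(=O)c3cccnc3)C(c3cn(C)c4ccc(Br)cc34)C2)cc(OC)c1OC` differs from compound 3 by 3,4,5-trimethoxyphenyl in place of 4-methoxyphenyl on a carbon with a double bond to nitrogen in one place: 3,4,5-trimethoxyphenyl in place of 4-methoxyphenyl on a carbon with a double bond to nitrogen. Going by the values given here, three measured steps bear on this, each an exchange on an aromatic carbon: a step that the two limits leave unreadable from compound 1 to compound 2 and a step that the two limits leave unreadable from compound 1 to compound 3 and a step that the two limits leave unreadable from compound 2 to compound 3 all lack a readable size. No step beyond the scatter is therefore expected in this assay in either direction. The estimate gives a number no higher from compound 3 to compound 4 (the limit leaves the size open) as the expected step. For compound 4 the estimated value is 300000 nM with an expected range from 150000 nM to 600000 nM and a further limit is the likeliest report.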

Compound 4, half-maximal cytotoxic concentration: 131000 nM
Beside the measured number, compound 4's estimate is 2.3-fold (0.36 log units) above it, outside the stated range (below it).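

In this assay, the carbon with a double bond to nitrogen now gives a first readable change, towards higher toxicity in this test: 3,4,5-trimethoxyphenyl in place of 4-methoxyphenyl gives an at least 2.2-fold lower number from compound 3 to compound 4 (0.35 log units; beyond the scatter). The same group gives an at least 2.2-fold lower number from compound 2 to compound 4 (0.35 log units; beyond the scatter) and an at least 2.2-fold lower number from compound 1 to compound 4 (0.35 log units; beyond the scatter), so the change appears against all three groups that leave. Compound 4 is the only compound shown that comes off the shared limit: the limit of > 300000 nM in this assay, at which 3 of the 4 values shown sit.

The steps among compound 1, compound 2 and compound 3 cannot be read. On these data alone, what an aminophenyl or a carboxyphenyl group would give at this position remains open.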